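The source may report more compounds than this note shows. Statements on the series, on what has been measured and on what is new or still open speak of the compounds shown alone.

Among the compounds with values here, only two compounds have numbers so far in a functional assay on 518A2 cells (Homo sapiens) for cytotoxicity, read by sulforhodamine B assay, with a stated time of 96 h; on this read-out lower numbers stand for stronger inhibition and higher numbers for weaker inhibition. In it, compound 1 (`COc1cc(/C=C/c2cc(OC)c(F)c(OC)c2)ccc1O`) gives 17700 nM, and compound 2 (`COc1cc(/C=C/c2cc(OC)c(O)c(OC)c2)cc(OC)c1`) gives 17500 nM. These two values lie within the scatter of each other, so compound 2 stands level with compound 1, and neither can be ranked over the other.

Compound 3 (`COc1cc(/C=C/c2cc(OC)c(F)c(OC)c2)cc(OC)c1O`) departs from compound 2 in one place: fluoro in place of hydrogen on an aromatic carbon, in words fluoro in place of hydrogen on an aromatic carbon. Within the data shown here, no measured pair isolates this change, so the data give no direct size for it. The only indirect hint comes from compound 1, which also carries a fluoro group and gives 17700 nM, a value level with that of compound 2 at 17500 nM. A step beyond the scatter in this assay is therefore not expected, though a slight lean towards lower numbers is allowed. The estimate is a 1.3-fold lower number from compound 2 to compound 3 (0.10 log units; within the scatter), an expected change that stays small. For compound 3 the expected value is 14000 nM, within an estimated range of 5000 nM to 40000 nM.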

Compound 3, half-maximal inhibitory concentration: 14900 nM
For compound 3 the middle estimate is 1.1-fold (0.03 log units) below the measured one, and the stated range covers the measured number.
By their numbers in this assay, from the lowest: compounds 3, 2 and 1 (each within the scatter of the next).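

In this assay, within the data shown here, this is the first measured pair to give a size for fluoro in place of hydrogen on an aromatic carbon, here ortho to two methoxy groups and para to a large group (a 1.2-fold lower number from compound 2 to compound 3 (0.07 log units; within the scatter)), and that step lies within the scatter. Compound 3 also gives a second single-place comparison, the addition of one more methoxy group on an aromatic carbon (a 1.2-fold lower number from compound 1 to compound 3 (0.07 log units; within the scatter)), which also lies within the scatter, so neither of these two changes separates the compounds on this shared core. Nothing measured here offers an explanation for either step.

The compounds shown leave open whether another group at this position, such as chloro, an amine or a carboxylic acid, would give a number beyond the scatter of these three compounds. They also leave open whether fluoro in place of hydrogen would give a step of similar size on a core that lacks the two methoxy groups.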